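Nitro in Place of Bromo on the Anilide of Compound 2

A few compounds are considered here, and "the series" means these few. Any claim that something is new, unique, unknown or untested is made for them only; others in the source may bear on it.

Compound 1, `COc1cc2c(cc1OC)C(CC(=O)O)CC2`: 44%
Compound 2, `COc1cc2c(cc1OC)C(CC(=O)Nc1ccc(Br)cc1)CC2`: 37.5%
Compound 3, `COc1cc2c(cc1OC)C(CC(=O)Nc1ccccc1C)CC2`: 30%

All three were measured in a functional assay on the whole organism (strain Swiss Albino) for inhibition, with Mus musculus as the target, in the writhing test, with a stated time of 1 h, at a dose of 100 mg/kg by the oral route; a higher number here means more inhibition at the dose given (going by the name of the read-out), a lower number less inhibition. Compound 2 stands second of the three numbers, but its gap to compound 1, a number 6.5 percentage points lower from compound 1 to compound 2 (within the scatter), and its gap to compound 3, a number 7.5 percentage points lower from compound 2 to compound 3 (within the scatter), both lie within the scatter, so no order among them can be claimed. Compound 4, `COc1cc2c(cc1OC)C(CC(=O)Nc1ccc([N+](=O)[O-])cc1)CC2`, differs from compound 2 by nitro in place of bromo on an aromatic carbon. Among the compounds with values here, no measured step swaps one group for another on the aryl ring of the amide; the only step touching that ring, from compound 2 to compound 3, stayed within the scatter, and a number 14 percentage points lower from compound 1 to compound 3 (beyond the scatter) was only modest. Compound 4 is therefore expected near 35%, within 20% to 50%. The expected step is a number 2.5 percentage points lower from compound 2 to compound 4 (within the scatter), within the scatter.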

Compound 4, a percentage reported as inhibition, in the whole organism at one dose (the size of the read-out at that dose, not a potency): 55.8%
For compound 4 the middle estimate is 20.8 percentage points below the measured one; the whole stated range lies below it.
By their numbers in this assay, from the lowest: compounds 3, 2 and 1 (each within the scatter of the next, the first and the last beyond it); then compound 4.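

Replacing bromo with nitro on this aromatic carbon, para to a large group, gives a number 18.3 percentage points higher from compound 2 to compound 4 (beyond the scatter) in this assay with the rest of compound 2 unchanged. Within the data shown here, this is the first step on the anilide ring to pass beyond the scatter, so what this carbon carries can change the inhibition seen at this dose. No evidence here bears on why the number rose.

The compounds shown leave open whether this gain is particular to nitro, or whether an amine or a nitrile on the same carbon would read alike in this assay and whether nitro would hold its number elsewhere on the ring.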